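The source may hold more compounds than are shown below. What is called first, only, known or untested is meant among the compounds shown, and "the series" means these compounds.

Measured compounds:
- Compound 1, `COC(=O)CNC1=CS(=O)(=O)O[C@@]12[C@@H](CO[Si](C)(C)C(C)(C)C)O[C@@H](n1cc(C)c(=O)n(C)c1=O)[C@@H]2O[Si](C)(C)C(C)(C)C`: in a functional assay on HEL cells (Homo sapiens) for cytotoxicity, read by microscopy (a higher number here means that more compound is tolerated, a lower number that less compound is tolerated), compound 1 gives a limit, >= 400000 nM.
- Compound 2, `CCNC(=O)NC1=CS(=O)(=O)O[C@@]12[C@@H](CO[Si](C)(C)C(C)(C)C)O[C@@H](n1cc(C)c(=O)n(C)c1=O)[C@@H]2O[Si](C)(C)C(C)(C)C`: in this assay compound 2 gives a limit, >= 3200 nM.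

Among the compounds with values here, compound 2 thus stands at a limit only, with no number of its own; the one step measured so far, a step that the two limits leave unreadable from compound 1 to compound 2, is unreadable as well. Compound 3, `Cc1cn([C@@H]2O[C@H](CO[Si](C)(C)C(C)(C)C)[C@@]3(OS(=O)(=O)C=C3NCCC(N)=O)[C@H]2O[Si](C)(C)C(C)(C)C)c(=O)n(C)c1=O`, is to be measured. The change is 2-carbamoylethyl in place of ethylcarbamoyl on an amine nitrogen. Within the data shown here, no measured step bears on a change of this kind, so the size of a step that the limit leaves unreadable from compound 2 to compound 3 is expected only loosely, with no direction favoured beyond the scatter. For compound 3 the estimate in this assay is 50000 nM, within 3200 nM to 400000 nM, most likely again reported as a limit.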

Compound 3, minimum cytotoxic concentration: >= 80000 nM
Compound 3 was reported as a limit (the forecaster's own chance of this, stated with the estimate: 80%); middle value at least 1.6-fold (0.20 log units) away from the limit.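

Within the data shown here, compound 1, compound 2 and compound 3 are all reported as limits in this assay, so no step among them can be read. Open, on these data alone, is whether ethylcarbamoyl, 2-carbamoylethyl or (methoxycarbonyl)methyl on the amine nitrogen changes tolerance at all.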